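Ester to amide on a potent GnRH receptor antagonist

The compounds below may be only part of what the source reports. "The series", "measured", "known", "first", "only" and "open" are said of these compounds alone.

Of the compounds shown here, three have been measured in an assay on HEK293 cells for binding affinity to Gonadotropin-releasing hormone receptor (Homo sapiens), read by radioligand binding; a higher number here means a weaker inhibitor, a lower number a stronger inhibitor. Compound 1 `CCC(CC)OC(=O)c1cn(Cc2ccccc2F)c2cc(-c3ccc(N)cc3)c(CN(C)Cc3ccccc3)n2c1=O` gives 100 nM. Compound 2 `CCCC(=O)Nc1ccc(-c2cc3n(Cc4ccccc4F)cc(C(=O)OC(CC)CC)c(=O)n3c2CN(C)Cc2ccccc2)cc1` gives 3.8 nM, and compound 3 `CCCC(=O)Nc1ccc(-c2cc3n(Cc4ccccc4F)cc(C(=O)OC(CC)CC)c(=O)n3c2CN(C)C)cc1` gives 130 nM. Compound 2 holds the lowest of the three numbers: the step from it is a 26-fold lower number from compound 1 to compound 2 (1.42 log units; beyond the scatter) and a 34-fold higher number from compound 2 to compound 3 (1.53 log units; beyond the scatter), each beyond the scatter.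

Compound 4 `CCCCNC(=O)c1cn(Cc2ccccc2F)c2cc(-c3ccc(NC(=O)CCC)cc3)c(CN(C)Cc3ccccc3)n2c1=O` differs from compound 2 by butylamino in place of (pentan-3-yl)oxy on a carbonyl carbon, a change on the carbonyl carbon whose other neighbours are an aromatic carbon. Neither measured step bears on this position; the two recorded steps concern the nitrogen on the aromatic ring and the saturated chain carbon bound to the amine nitrogen, and both were large. For the ester-to-amide exchange there is no guide among these compounds, so the size of the step in this assay cannot be read from them. Compound 4 is therefore expected to stay near compound 2, with a modest loss allowed, estimated at 10 nM within 2 nM to 60 nM, an expected step of a 2.6-fold higher number from compound 2 to compound 4 (0.42 log units; beyond the scatter).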

Compound 4, inhibition constant: 154 nM
Compound 4: the middle estimate sits 15-fold (1.19 log units) below what was measured; measured number above the stated range.
By their numbers in this assay, from the lowest: compound 2; then compounds 1, 3 and 4 (each within the scatter of the next).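

In this assay, the carbonyl carbon proves to be a sensitive position: butylamino in place of (pentan-3-yl)oxy gives a 41-fold higher number from compound 2 to compound 4 (1.61 log units; beyond the scatter), so the ester-bearing compound 2 cannot be exchanged to this amide without a large loss. This adds a third place on the shared core where a single change produces a large step, alongside the nitrogen on the aromatic ring and the saturated chain carbon bound to the amine nitrogen. Nothing in the data says why the step is so large.

The entering group differs from the leaving one in both its linking atom and its chain, so this single step cannot separate the two. An amide carrying the pentan-3-yl group, or an ester carrying a butyl chain, would tell them apart, and a tertiary amide with an added methyl on the nitrogen would test the amide hydrogen.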